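Amide Aryl Swap in an Antiproliferative Series

This account rests on a few compounds, and the source may have more. Where it says the series, first, only, none or still open, it means among the compounds named here.

Compound 1 `O=C(Nc1cccc(-c2oc3cc(-c4ccc(F)cc4)ccc3c(=O)c2O)c1)c1ccc(Cl)cc1`: 11000 nM
Compound 2 `COc1ccc(C(=O)Nc2cccc(-c3oc4cc(-c5ccc(F)cc5)ccc4c(=O)c3O)c2)c(F)c1`: 45300 nM

Of the compounds shown here, two sharing one core have been measured in a functional assay on HepG2 cells (Homo sapiens) for antiproliferative activity, read by CCK-8 assay, with a stated time of 72 h; on this read-out higher numbers stand for weaker inhibition and lower numbers for stronger inhibition. Compound 1, with 4-chlorophenyl on the carbonyl carbon, gives 11000 nM. Going by the values given here, compound 2 gives 45300 nM and stands highest of the two numbers; the single measured step, a 4.1-fold higher number from compound 1 to compound 2 (0.61 log units; beyond the scatter), lies beyond the scatter and is the only comparison available.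

Compound 3 `CCCc1ccc(C(=O)Nc2cccc(-c3oc4cc(-c5ccc(F)cc5)ccc4c(=O)c3O)c2)cc1` has not yet been measured. It differs from compound 2 in one place: 4-propylphenyl in place of 2-fluoro-4-methoxyphenyl on a carbonyl carbon. Among the compounds with values here, no measured step covers 4-propylphenyl itself, so the expectation leans on the one step available: the 2-fluoro-4-methoxyphenyl group that leaves compound 2 is the group whose entry produced the higher number in a 4.1-fold higher number from compound 1 to compound 2 (0.61 log units; beyond the scatter), and compound 3 carries instead a group without that substitution pattern, as in compound 1, which gives 11000 nM. Compound 3 is therefore expected to return part of the way toward the number of compound 1, a step of about a 3.0-fold lower number from compound 2 to compound 3 (0.48 log units; beyond the scatter). The estimate for compound 3 in this assay is 15000 nM, with a range from 5000 nM to 50000 nM.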

Compound 3, half-maximal inhibitory concentration: 51500 nM
Beside the measured number, compound 3's estimate is 3.4-fold (0.54 log units) below it, and the stated range ends below it.
By their numbers in this assay, from the lowest: compound 1; then compounds 2 and 3 (each within the scatter of the next).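

In this assay, exchanging 2-fluoro-4-methoxyphenyl for 4-propylphenyl on the carbonyl carbon gives a 1.1-fold higher number from compound 2 to compound 3 (0.06 log units; within the scatter) and so leaves the read-out unmoved within the scatter, even though one group carries oxygen and fluorine and the other is carbon only. Propyl in place of chloro on the aromatic carbon gives a 4.7-fold higher number from compound 1 to compound 3 (0.67 log units; beyond the scatter) and thus shows that the higher number seen for compound 2 is not peculiar to the 2-fluoro-4-methoxyphenyl group, leaving compound 1, with its 4-chlorophenyl group, as the most potent of the three. No supporting data accompany these numbers to account for the difference.

Going by these compounds, what remains open is whether chloro is itself special at this place or whether other small atoms or groups on the same aromatic carbon, such as bromo, methyl or trifluoromethyl, would give numbers like that of compound 1. On these data alone, it is also open how a shorter ethyl chain, an amine or a carboxylic acid in that spot would read out, and whether the order of these three compounds would hold in other cell lines.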